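The compounds below may be only part of what the source reports. "The series", "measured", "known", "first", "only" and "open" are said of these compounds alone.

Compound 1 `Cc1ccc(S(=O)(=O)N2CC[C@@H](Br)C[C@@H]2CC(C)C)cc1` gives 39000 nM in a functional assay on A2780 cells (Homo sapiens) for antiproliferative activity, read by sulforhodamine B assay, with a stated time of 48 h; a higher number here means a weaker inhibitor of growth, a lower number a stronger inhibitor of growth. Compound 2 `Cc1ccc(S(=O)(=O)N2CC[C@@H](Br)C[C@@H]2c2ccccc2)cc1` reaches only the assay limit, > 100000 nM. The step of an at least 2.5-fold higher number from compound 1 to compound 2 (0.40 log units; beyond the scatter) shows that a phenyl in place of an isobutyl weakens growth inhibition, and two of the three measured values sit at the limit of > 100000 nM in this assay, at which 2 of the 3 values shown sit. Compound 3 `Cc1ccc(S(=O)(=O)N2CC=C(Cl)CC2)cc1`, carrying neither group, also stands at the limit in this assay, > 100000 nM. Compound 4 `Cc1ccc(S(=O)(=O)N2CCC(Cl)=CC2C2CCCCC2)cc1` differs from it by cyclohexyl in place of hydrogen on a saturated ring carbon. Among the compounds with values here, the single measured step concerns a different swap of large groups, so it bears on this change only indirectly; cyclohexyl, like isobutyl, is a saturated carbon-only group, yet compound 3 already lies at the limit. Compound 4 is therefore expected near 70000 nM, between 20000 nM and 250000 nM, an estimated step of an at least 1.4-fold lower number from compound 3 to compound 4 (0.15 log units; that floor lies within the scatter).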

Compound 4, concentration for 50% growth inhibition: 39000 nM
Compound 4: the middle estimate sits 1.8-fold (0.25 log units) above what was measured; the measured number falls inside the stated range.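

Cyclohexyl in place of hydrogen on a saturated ring carbon, next to the ring nitrogen, gives an at least 2.5-fold lower number from compound 3 to compound 4 (0.40 log units; beyond the scatter) in this assay. The earlier step only compared two large groups, whereas this one shows that putting a large group on this carbon, rather than leaving hydrogen there, can itself strengthen growth inhibition. The value of compound 3 is a limit, so this step is only a floor: the limit of > 100000 nM in this assay, at which 2 of the 4 values shown sit.

As far as these compounds go, whether a methyl, a hydroxyl or an amine on this carbon would also lower the number remains open. So does the effect of a phenyl here alongside the chloro group.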